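The compounds below may be only part of what the source reports. "The series", "measured", "known", "first", "only" and "open" are said of these compounds alone.

Measured in a functional assay on A2780 cells (Homo sapiens) for inhibition, read by MTT assay, with a stated time of 72 h; on this read-out lower numbers stand for stronger inhibition of growth and higher numbers for weaker inhibition of growth:
compound 1 `O=S(=O)(NCCCNCc1ccccc1Cl)c1cc(C(F)(F)F)cc(C(F)(F)F)c1` gives 9300 nM
compound 2 `CC(C)(C)c1ccc(CNCCCNS(=O)(=O)c2cc(C(F)(F)F)cc(C(F)(F)F)c2)cc1` gives 2900 nM
compound 3 `O=S(=O)(NCCCNCc1ccccc1)c1cc(C(F)(F)F)cc(C(F)(F)F)c1` gives 4900 nM

On these numbers compound 3 stands second highest of three, yet its gaps to compound 2 and to compound 1 both lie within the scatter, so nothing separates them. Compound 4 `O=S(=O)(NCCCNCc1ccc(Cl)cc1)c1cc(C(F)(F)F)cc(C(F)(F)F)c1` differs from compound 3 by chloro in place of hydrogen on an aromatic carbon. Among the compounds with values here, two measured steps bear on this. Taking away the chloro of compound 1, which sits elsewhere on the ring, gave a 1.9-fold lower number from compound 1 to compound 3 (0.28 log units; within the scatter). Taking away the tert-butyl of compound 2, which sits where the new chloro enters, gave a 1.7-fold higher number from compound 2 to compound 3 (0.23 log units; within the scatter), a small move in the opposite sense. Both moves sit within the scatter, so the added chloro is expected to change little. Compound 4 is therefore expected to give 3500 nM, between 1500 nM and 8000 nM, a step of a 1.4-fold lower number from compound 3 to compound 4 (0.15 log units; within the scatter) in this assay.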

Compound 4, concentration for 50% growth inhibition: 1800 nM
Compound 4: middle estimate off by 1.9-fold (0.29 log units), on the high side; low and high end bracket the measured number.
By their numbers in this assay, from the lowest: compounds 4, 2, 3 and 1 (each within the scatter of the next, the first and the last beyond it).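

Chloro at this place, para to a large group, gives a step beyond the scatter, a 2.7-fold lower number from compound 3 to compound 4 (0.43 log units; beyond the scatter), so this position responds to a single added atom. Where the chloro sits also counts: a 5.2-fold lower number from compound 1 to compound 4 (0.71 log units; beyond the scatter) is likewise beyond the scatter, with only the chloro's place on the ring changed. Chloro and the much larger tert-butyl cannot be told apart here, as a 1.6-fold lower number from compound 2 to compound 4 (0.21 log units; within the scatter) lies within the scatter.

Nothing measured here explains the effect of the chloro. As far as these compounds go, whether fluoro, methoxy or an amine at this same place would match chloro remains open.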